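Piperidine amine series: arylmethyl variants in the binding assay

A few compounds are considered here, and "the series" means these few. Any claim that something is new, unique, unknown or untested is made for them only; others in the source may bear on it.

Measured compounds:
compound 1, `O[C@H]1Cc2ccccc2C1NC1CCN(CCCc2c[nH]c3ccc(-n4cnnc4)cc23)CC1`, in a binding assay on CHO cells for displacement of a labelled ligand from 5-hydroxytryptamine receptor 1B (Homo sapiens); a lower number here means a stronger inhibitor, a higher number a weaker inhibitor: 300 nM
compound 2, `CC(=O)Nc1ccc(CNC2CCN(CCCc3c[nH]c4ccc(-n5cnnc5)cc34)CC2)cc1`: 45 nM
compound 3, `CN(Cc1ccsc1)C1CCN(CCCc2c[nH]c3ccc(-n4cnnc4)cc23)CC1`: 35 nM

Compound 3 gives the lowest number of the three in this assay; compound 2 sits within the scatter of it, while compound 1 stands beyond the scatter from both. The two measured steps both start from compound 1: a 6.7-fold lower number from compound 1 to compound 2 (0.82 log units; beyond the scatter) and an 8.6-fold lower number from compound 1 to compound 3 (0.93 log units; beyond the scatter). Both replacements of the 2-hydroxy-2,3-dihydro-1H-inden-1-yl group by an arylmethyl group brought a modest gain of similar size.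

Compound 4, `CC(=O)Nc1ccc(CN(C)C2CCN(CCCc3c[nH]c4ccc(-n5cnnc5)cc34)CC2)cc1`, has not been measured. It differs from compound 3 as follows: 4-acetamidophenyl in place of thiophen-3-yl on a saturated chain carbon bound to an amine nitrogen. Compound 4 thus carries the 4-acetamidobenzyl of compound 2 together with the methyl on the amine nitrogen seen in compound 3. Going by the values given here, no step between compound 2 and compound 4 is measured; what their pair shows can only be read once compound 4 is known. The two measured steps bear on the change indirectly: they show that the thiophen-3-ylmethyl and 4-acetamidobenzyl groups give numbers within the scatter of each other on the shared core. Hence the step is expected to stay within the scatter: no change at the digits printed from compound 3 to compound 4 (within the scatter). Compound 4 is estimated at 35 nM, with a range of 12 nM to 100 nM.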

Compound 4, half-maximal inhibitory concentration: 100 nM
Compound 4: middle estimate off by 2.9-fold (0.46 log units), on the low side; the range from low to high includes it.
By their numbers in this assay, from the lowest: compounds 3 and 2 (each within the scatter of the next); then compound 4; then compound 1.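

With the methyl kept on the amine nitrogen, changing (thiophen-3-yl)methyl to 4-acetamidobenzyl gives a 2.9-fold higher number from compound 3 to compound 4 (0.46 log units; beyond the scatter) in this assay, so at this position the choice of arylmethyl group moves the number by a modest step beyond the scatter. Going by these compounds alone, with 4-acetamidobenzyl kept in place, putting methyl in place of hydrogen on the amine nitrogen gives a 2.2-fold higher number from compound 2 to compound 4 (0.35 log units; beyond the scatter), the first single-place reading of this change, and it too is modest and beyond the scatter; the earlier compounds isolated neither change, as their measured steps all start from the 2-hydroxy-2,3-dihydro-1H-inden-1-yl group of compound 1. No measurement at hand accounts for either step.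

Still open, going by these compounds, is whether the higher number of compound 4 tracks the acetamido group or the phenyl ring itself, a question that a plain benzyl or a 4-methoxybenzyl group on the same amine nitrogen would address. Also open, on these data alone, is whether the methyl step carries over to the (thiophen-3-yl)methyl group, and how an ethyl on the amine nitrogen would compare with methyl and hydrogen.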